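The source may hold more compounds than are shown below. What is called first, only, known or untested is meant among the compounds shown, and "the series" means these compounds.

Compound 1 `CCCCNC(=O)N1CC1C#N` carries a butyl group on the urea nitrogen of the shared core. In a functional assay on WiDr cells (Homo sapiens) for inhibition (on this read-out higher numbers stand for weaker inhibition and lower numbers for stronger inhibition), compound 1 gives 18000 nM, the higher of the two numbers recorded, while compound 2 `N#CC1CN1C(=O)Nc1ccc([N+](=O)[O-])cc1` gives 3700 nM in this assay, a difference beyond the scatter. Compound 3 `N#CC1CN1C(N)=O` differs from compound 1 by hydrogen in place of butyl on an amide-type nitrogen. Going by the values given here, no measured step of this kind exists here, so the direction rests on the two values alone. Removing the butyl chain is expected to weaken inhibition, a step of a 2.2-fold higher number from compound 1 to compound 3 (0.35 log units; beyond the scatter) just beyond the scatter. Compound 3 is therefore estimated at 40000 nM, with a range from 12000 nM to 130000 nM.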

Compound 3, half-maximal inhibitory concentration: > 280000 nM
Compound 3: a limit, no number (the forecaster's own chance of this, stated with the estimate: 30%); at least 7.0-fold (0.84 log units) between middle value and limit.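

Hydrogen in place of butyl on an amide-type nitrogen gives an at least 15-fold higher number from compound 1 to compound 3 (1.19 log units; beyond the scatter) in this assay and so shows that inhibition depends strongly on what this nitrogen carries. The result for compound 3 is a limit and not a number, so the full size of the step stays open: the limit of > 280000 nM in this assay, at which 1 of the 3 values shown sits.

On these data alone, whether a shorter chain such as methyl or a longer chain such as hexyl would keep the inhibition of compound 1 remains open. The compounds shown also leave open how a butyl chain ending in an amine would compare.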